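The compounds below may be only part of what the source reports. "The series", "measured", "known", "first", "only" and "open" are said of these compounds alone.

The measured compounds in a functional assay on the whole organism (strain albino) for inhibition, with Rattus norvegicus as the target, read by paw edema, with stated times of 1 h and 0.5 h, at a dose of 100 mg/kg by the oral route; on this read-out lower numbers stand for less inhibition and higher numbers for more inhibition at the one dose given (going by the name of the read-out):

compound 1 `Cn1c(SCC(=O)Nn2c(COc3ccc(Cl)cc3Cl)nc3ccccc3c2=O)nc(-c2ccc(Cl)cc2)c(C#N)c1=O` gives 80.8%
compound 2 `Cn1c(SCC(=O)Nn2c(COc3ccc(Cl)cc3Cl)nc3ccccc3c2=O)nc(-c2ccc(O)cc2)c(C#N)c1=O` gives 76.9%
compound 3 `N#Cc1c(Nc2ccccc2)nc(SCC(=O)Nn2c(COc3ccc(Cl)cc3Cl)nc3ccccc3c2=O)nc1-c1ccc(Cl)cc1` gives 36.5%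

Compound 1 and compound 2 share one core and differ by hydroxy in place of chloro on an aromatic carbon. That change produced a number 3.9 percentage points lower from compound 1 to compound 2 (within the scatter). Compound 3 is built on a different core, and the difference between the two cores is not broken down here. Its value in this assay lies well below those of compound 1 and compound 2, with the gap to each beyond the scatter.

Compound 4 `N#Cc1c(Nc2ccccc2)nc(SCC(=O)Nn2c(COc3ccc(Cl)cc3Cl)nc3ccccc3c2=O)nc1-c1ccc(O)cc1` has not yet been measured. It stands to compound 3 as compound 2 stands to compound 1: the difference is hydroxy in place of chloro on an aromatic carbon, the same change at the same place, occurring twice among these compounds. Since that change gave a number 3.9 percentage points lower from compound 1 to compound 2 (within the scatter) in the first pair, a step of similar small size is expected in the second pair, though the core of compound 3 is different and the outcome is not certain. In this assay compound 4 is expected to give 34%, between 20% and 50%. The expected step is a number 2.5 percentage points lower from compound 3 to compound 4 (within the scatter), resting on the measured a number 3.9 percentage points lower from compound 1 to compound 2 (within the scatter).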

Compound 4, a percentage reported as inhibition, in the whole organism at one dose (the size of the read-out at that dose, not a potency): 90.4%
Compound 4: middle estimate off by 56.4 percentage points, on the low side; the whole stated range lies below it.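

In this assay, the change from 4-chlorophenyl to 4-hydroxyphenyl gave a number 53.9 percentage points higher from compound 3 to compound 4 (beyond the scatter), so the small step seen on the core of compound 1 did not carry over to the core of compound 3. In this series, the step read on one core therefore gave no safe guide to the step on the other, and the two steps differ clearly: the same change on two cores in this assay, a number 3.9 percentage points lower (within the scatter) from compound 1 to compound 2 and a number 53.9 percentage points higher (beyond the scatter) from compound 3 to compound 4, 57.8 percentage points apart, beyond the scatter of two such steps

These two pairs do not show which feature of the cores goes with the difference, and they offer no rule for any further core.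

Only chloro and hydroxy appear in this place among the compounds shown, so it remains open whether the large step on the core of compound 3 is particular to hydroxy or would also appear with a methoxy group or an amine. Going by these compounds, it also remains open how the same exchange would behave on a core carrying a morpholine or a longer chain in place of the phenylamino group of compound 3.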